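The source may hold more compounds than are shown below. What is called first, only, known or untested is meant among the compounds shown, and "the series" means these compounds.

Among the measured compounds shown here, compound 3 `CN1[C@@H]2c3[nH]c4ccccc4c3C[C@H]1[C@H](C#N)N1[C@@H](CNC(=O)c3ccc4ccccc4c3)c3[nH]c4ccccc4c3C[C@@H]21` shows 1030 nM in a functional assay on A2780 cells (Homo sapiens) for cytotoxicity, read by MTT assay, with a stated time of 72 h (on this read-out lower numbers stand for stronger inhibition and higher numbers for weaker inhibition), the highest of the three numbers known so far. Compound 1 `CN1[C@@H]2c3[nH]c4ccccc4c3C[C@H]1[C@H](C#N)N1[C@@H](CNC(=O)c3cccc(C(F)(F)F)c3)c3[nH]c4ccccc4c3C[C@@H]21` gives 210 nM, and compound 2 `CCc1ccc(C(=O)NC[C@H]2c3[nH]c4ccccc4c3C[C@H]3[C@H]4c5[nH]c6ccccc6c5C[C@@H]([C@H](C#N)N23)N4C)cc1` gives 670 nM. The change to compound 4 `CN1[C@@H]2c3[nH]c4ccccc4c3C[C@H]1[C@H](C#N)N1[C@@H](CNC(=O)c3ccc4ccccc4n3)c3[nH]c4ccccc4c3C[C@@H]21` is quinolin-2-yl in place of naphthalen-2-yl on a carbonyl carbon. Every measured step alters this same group on the carbonyl carbon: a 4.9-fold higher number from compound 1 to compound 3 (0.69 log units; beyond the scatter), a 3.2-fold higher number from compound 1 to compound 2 (0.50 log units; beyond the scatter) and a 1.5-fold higher number from compound 2 to compound 3 (0.19 log units; within the scatter). None of them exchanges a ring carbon for a ring nitrogen, so the direction of the new step cannot be read from them. Since the swap between two bicyclic ring groups, a 1.5-fold higher number from compound 2 to compound 3 (0.19 log units; within the scatter), stayed within the scatter, compound 4 is expected to give roughly 900 nM, with a range from 350 nM to 2500 nM. The expected step is a 1.1-fold lower number from compound 3 to compound 4 (0.06 log units; within the scatter).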

Compound 4, half-maximal inhibitory concentration: 60 nM
Compound 4: the middle estimate sits 15-fold (1.18 log units) above what was measured, outside the stated range (below it).
By their numbers in this assay, from the lowest: compound 4; then compound 1; then compounds 2 and 3 (each within the scatter of the next).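

Exchanging one ring carbon for a ring nitrogen matters greatly at this position: quinolin-2-yl has the same heavy-atom count as naphthalen-2-yl, yet it gives a 17-fold lower number from compound 3 to compound 4 (1.23 log units; beyond the scatter). The same group on the carbonyl carbon also outperforms 4-ethylphenyl, with an 11-fold lower number from compound 2 to compound 4 (1.05 log units; beyond the scatter), and 3-(trifluoromethyl)phenyl, with a 3.5-fold lower number from compound 1 to compound 4 (0.54 log units; beyond the scatter), making compound 4 the most active of the four. No evidence here explains the effect of this nitrogen.

The compounds shown leave open whether the gain needs the second ring, which pyridin-2-yl could test, and whether the nitrogen's place in the ring matters, which quinolin-3-yl could test.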